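Notes on compounds 1 to 3: aryl change on the sulfonyl sulfur

The source may hold more compounds than are shown below. What is called first, only, known or untested is meant among the compounds shown, and "the series" means these compounds.

Compound 1 `CC(=O)Nc1ccc(S(=O)(=O)NNC(=O)c2cccnc2Nc2ccc(Cl)cc2)cc1` was run in a functional assay on SNB-19 cells (Homo sapiens) for antiproliferative activity; a lower number here means that less compound is tolerated, a higher number that more compound is tolerated. In this assay compound 1 gives > 100000 nM, which is a limit of the assay and not a number. Compound 2 `O=C(NNS(=O)(=O)c1ccc(F)cc1)c1cccnc1Nc1ccc(Cl)cc1Cl` in this assay gives > 100000 nM, likewise a limit. Compound 1 therefore sits at the limit of > 100000 nM in this assay, at which 2 of the 2 values shown sit. Compound 3 `O=C(NNS(=O)(=O)c1ccc(Cl)cc1Cl)c1cccnc1Nc1ccc(Cl)cc1` carries 2,4-dichlorophenyl in place of 4-acetamidophenyl on a sulfonyl sulfur. Among the measured compounds shown here, no step between measured compounds is available, so no change beyond the scatter is expected, and a limit again is the likeliest outcome. For compound 3 the estimate is 100000 nM, expected to fall between 30000 nM and 300000 nM, corresponding to an expected step of a number no higher from compound 1 to compound 3 (the limit leaves the size open).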

Compound 3, concentration lethal to 50% of the cells: > 100000 nM
Compound 3 was reported as a limit; the forecaster's own chance of this, stated with the estimate: 75%; the middle value lies on the limit itself.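

Compound 1 and compound 3 both stand at a limit in this assay, so no step can be read between them. The compounds shown leave open whether 2,4-dichlorophenyl in place of 4-acetamidophenyl changes the read-out at all.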